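A few compounds are considered here, and "the series" means these few. Any claim that something is new, unique, unknown or untested is made for them only; others in the source may bear on it.

Measured in a functional assay on MGC-803 cells (Homo sapiens) for cytotoxicity, read by MTT assay, with a stated time of 72 h; a higher number here means a weaker inhibitor, a lower number a stronger inhibitor:
Compound 1 `FC(F)(F)c1ccc(CSc2nc(N3CCCCC3)c3ccccc3n2)cc1`: 18600 nM
Compound 2 `FC(F)(F)c1ccc(CSc2nc(Nc3ccccc3Cl)c3ccccc3n2)cc1`: > 50000 nM, a limit of the assay rather than a number.
Compound 3 `O=[N+]([O-])c1cccc(Nc2nc(SCc3ccc(C(F)(F)F)cc3)nc3ccccc23)c1`: > 50000 nM, likewise a limit of the assay.

Among the measured compounds shown here, compound 1 carries the only real number in this set; the other two values are limits (the limit of > 50000 nM in this assay, at which 2 of the 3 values shown sit). Compound 4 `O=[N+]([O-])c1ccc(Nc2nc(SCc3ccc(C(F)(F)F)cc3)nc3ccccc23)cc1` differs from compound 1 by (4-nitrophenyl)amino in place of piperidin-1-yl on an aromatic carbon. For the measured compounds named here, two measured steps bear on this change, both swapping the same piperidin-1-yl for an arylamino group: an at least 2.6-fold higher number from compound 1 to compound 2 (0.42 log units; beyond the scatter) and an at least 2.6-fold higher number from compound 1 to compound 3 (0.42 log units; beyond the scatter). Both went the same way, towards weaker inhibition, and neither gave a readable number. The same direction is expected for compound 4, with a step of a 2.7-fold higher number from compound 1 to compound 4 (0.43 log units; beyond the scatter) in this assay. Compound 4 is therefore estimated at 50000 nM, between 18000 nM and 150000 nM, and it may well come back only as a limit.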

Compound 4, half-maximal inhibitory concentration: 8170 nM
Compound 4: middle estimate off by 6.1-fold (0.79 log units), on the high side; the measured number lies below the stated range.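

The arylamino swap does not always weaken at this position: the 4-nitrophenyl group gives a 2.3-fold lower number from compound 1 to compound 4 (0.36 log units; beyond the scatter), the opposite direction to the two earlier swaps. The ring on that nitrogen therefore matters, since moving the nitro group gives an at least 6.1-fold lower number from compound 3 to compound 4 (0.78 log units; beyond the scatter), and replacing 2-chlorophenyl gives an at least 6.1-fold lower number from compound 2 to compound 4 (0.78 log units; beyond the scatter). Compound 2 and compound 3 stand only as limits, so the step between them cannot be read: the limit of > 50000 nM in this assay, at which 2 of the 4 values shown sit.

Going by these compounds, whether the nitro group itself is needed stays open. A 4-chlorophenyl or 4-methoxyphenyl group on the same nitrogen could separate the group's identity from its place on the ring.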